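From 2-chlorobenzyl to 4-bromobenzyl: compound 2 to compound 3

The compounds below may be only part of what the source reports. "The series", "measured", "known", "first", "only" and "open" are said of these compounds alone.

In a functional assay, read by spectrophotometry, with a stated time of 30 min (a higher number here means a weaker inhibitor, a lower number a stronger inhibitor), compound 1 (`CC(C)(C)c1cc(/C=C/C(=O)NCCC2CCN(Cc3cccc(F)c3)CC2)cc(C(C)(C)C)c1O`) gives 55200 nM and compound 2 (`CC(C)(C)c1cc(/C=C/C(=O)NCCC2CCN(Cc3ccccc3Cl)CC2)cc(C(C)(C)C)c1O`) gives 80200 nM. For the measured compounds named here, compound 2 holds the higher of only two numbers, but the two lie within the scatter of each other. Compound 3 (`CC(C)(C)c1cc(/C=C/C(=O)NCCC2CCN(Cc3ccc(Br)cc3)CC2)cc(C(C)(C)C)c1O`) remains unmeasured. Its difference from compound 2 is 4-bromophenyl in place of 2-chlorophenyl on a saturated chain carbon bound to an amine nitrogen in a ring. Going by the values given here, one measured step bears on this place: a 1.5-fold higher number from compound 1 to compound 2 (0.16 log units; within the scatter), which stays within the scatter. Among the compounds with values here, no measured compound carries 4-bromophenyl, so this evidence is thin. No change beyond the scatter is therefore expected in this assay, in either direction. The expected step is a 1.2-fold lower number from compound 2 to compound 3 (0.09 log units; within the scatter). Compound 3 is estimated at 65000 nM, with an expected range of 25000 nM to 150000 nM.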

Compound 3, half-maximal inhibitory concentration: 85600 nM
The estimate for compound 3 lay 1.3-fold (0.12 log units) below the measured number, within the range that was stated.
By their numbers in this assay, from the lowest: compounds 1, 2 and 3 (each within the scatter of the next).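

In this assay, 4-bromophenyl in place of 2-chlorophenyl on a saturated chain carbon bound to an amine nitrogen in a ring gives a 1.1-fold higher number from compound 2 to compound 3 (0.03 log units; within the scatter), and 4-bromophenyl in place of 3-fluorophenyl at the same place gives a 1.6-fold higher number from compound 1 to compound 3 (0.19 log units; within the scatter). For the compounds shown here, the position now carries three different halogens at three different named placings on the phenyl, and no step among compound 1, compound 2 and compound 3 leaves the scatter, so neither the kind of halogen nor its placing separates these compounds in this assay. No measurement at hand bears on why these numbers stay so close.

From the compounds shown here alone, whether a phenyl with no halogen, or one carrying an amine or a carboxylic acid, would move the number beyond the scatter remains open. Also open, going by these compounds, is whether any change in the shared core would do so.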